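Series notes: aryl swap from compound 2 to compound 4

The compounds below may be only part of what the source reports. "The series", "measured", "known", "first", "only" and "open" are said of these compounds alone.

Of the compounds shown here, three of this core have been measured in an assay on HBE cells for positive allosteric modulation of Cystic fibrosis transmembrane conductance regulator variant F508del (Homo sapiens); on this read-out lower numbers stand for smaller maximal responses and higher numbers for larger maximal responses. Compound 1 `COc1ccc(Cl)cc1CN[C@H]1[C@H](C(C)(C)C)[C@@H](C(=O)O)N(C(=O)C2CCCCC2)[C@H]1c1ccccc1` gives 109%, compound 2 `COc1ccc(C(C)C)cc1CN[C@H]1[C@H](C(C)(C)C)[C@@H](C(=O)O)N(C(=O)C2CCCCC2)[C@H]1c1ccccc1` gives 191%, and compound 3 `COc1ccc(C23CC4CC42C3)cc1CN[C@H]1[C@H](C(C)(C)C)[C@@H](C(=O)O)N(C(=O)C2CCCCC2)[C@H]1c1ccccc1` gives 173%. Compound 2 stands highest of the three: the gap to compound 3 is beyond the scatter, as is the gap to compound 1. The measured steps all concern the group on the aromatic carbon: a number 82 percentage points higher from compound 1 to compound 2 (beyond the scatter), a number 64 percentage points higher from compound 1 to compound 3 (beyond the scatter), and a number 18 percentage points lower from compound 2 to compound 3 (beyond the scatter).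

Compound 4 `COc1ncc(C(C)(C)C)cc1CN[C@H]1[C@H](C(C)(C)C)[C@@H](C(=O)O)N(C(=O)C2CCCCC2)[C@H]1c1ccccc1` is not yet measured. Its difference from compound 2 is a group of 12 heavy atoms (10 carbon, 1 nitrogen, 1 oxygen; one six-membered aromatic ring with 1 hetero atom) in place of a group of 11 heavy atoms (10 carbon, 1 oxygen; one six-membered aromatic ring of carbon only), on a saturated chain carbon bound to an amine nitrogen. Going by the values given here, the steps from compound 1 to compound 2 and from compound 2 to compound 3 show that changing the group on the aromatic carbon moves the maximal response substantially, but none of the measured steps exchanges a ring carbon for a nitrogen atom, so that part of the change is uncovered. A modest change in this assay, in either direction, or none beyond the scatter is expected; the estimated step is a number 21 percentage points lower from compound 2 to compound 4 (beyond the scatter). Compound 4 is estimated at 170%, with a range from 120% to 210%.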

Compound 4, largest response reached (reported as percent of maximum), in percent of the reference or control that the assay uses: 114%
Estimate against measurement, compound 4: 56 percentage points above, and the stated range ends above it.
By their numbers in this assay, from the lowest: compounds 1 and 4 (each within the scatter of the next); then compound 3; then compound 2.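

In this assay, replacing the 5-isopropyl-2-methoxyphenyl group on a saturated chain carbon bound to an amine nitrogen gives a number 77 percentage points lower from compound 2 to compound 4 (beyond the scatter), so this position does not tolerate every change that keeps a branched alkyl group on the aromatic ring. The comparison with the chloro compound reads a number 5 percentage points higher from compound 1 to compound 4 (within the scatter), which places the new ring, with its hetero atom and tert-butyl group, level with chloro rather than with isopropyl. Nothing measured here explains the loss.

The entering group differs from the leaving one in both the ring nitrogen and the tert-butyl group, so the step cannot assign the loss to either change alone. As far as these compounds go, it also remains open how the ring with the hetero atom behaves when it carries isopropyl, cyclopropyl or trifluoromethyl instead.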